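A few compounds are considered here, and "the series" means these few. Any claim that something is new, unique, unknown or untested is made for them only; others in the source may bear on it.

In a functional assay on B16 cells (Mus musculus) for cytotoxicity, read by MTT assay, with a stated time of 48 h (a higher number here means a weaker inhibitor, a lower number a stronger inhibitor), three compounds have been tested, and none gave a number. Compound 1 `COc1ccc(-c2cn(C[C@H]3COC(C)(C)O3)nn2)cc1` reached only the limit of the assay, > 100000 nM. Compound 2 `CCOC(=O)Cn1cc(C(O)c2ccc3ccccc3c2)nn1` likewise stopped at the limit, > 100000 nM. Compound 3 `COc1cccc(Cn2cc(-c3ccc4ccccc4c3)nn2)c1` also sits at the limit, > 100000 nM, so its standing is not a measured value but the edge of what this assay reports, and the same holds for the other two values shown (the limit of > 100000 nM in this assay, at which 3 of the 3 values shown sit).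

The next compound, compound 4 `CCOC(=O)Cn1cc(-c2ccc3ccccc3c2)nn1`, differs from compound 3 in one place: ethoxycarbonyl in place of 3-methoxyphenyl on a saturated chain carbon bound to an aromatic nitrogen. Compound 2 already carries this ethoxycarbonyl group without a number emerging. The step from compound 3 to compound 4 is therefore expected to be none beyond the scatter a step that the limit leaves unreadable from compound 3 to compound 4. Compound 4 is estimated at 150000 nM, within 50000 nM to 500000 nM, most likely again reported only as a limit.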

Compound 4, half-maximal inhibitory concentration: > 100000 nM
Compound 4 gave a limit, no number; the forecaster's own chance of this, stated with the estimate: 85%; the middle value is on the limit's open side.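

Compound 3 and compound 4 both stand at a limit of the assay, not a number, so no step between them can be read: the limit of > 100000 nM in this assay, at which 4 of the 4 values shown sit.

Which change, if any, would give a measured number in this assay remains open for these compounds.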